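The source may report more compounds than this note shows. Statements on the series, on what has been measured and on what is new or still open speak of the compounds shown alone.

Measured in an ADME assay for permeability, using PAMPA, at pH 7.4; on this read-out lower numbers stand for lower permeability and higher numbers for higher permeability:
- compound 1 `Cc1cc(NC(=O)Nc2ccc(N(C)C)cc2)c2ccccc2n1`: 2 10^-6 cm/s
- compound 2 `Cc1cc(NC(=O)Nc2ccc(O)cc2)c2ccccc2n1`: 3 10^-6 cm/s

Compound 2 and compound 1 lie within the scatter of each other, so neither leads the pair. Compound 3 `Cc1cc(NC(=O)Nc2ccc(SC(F)(F)F)cc2)c2ccccc2n1` carries (trifluoromethyl)sulfanyl in place of hydroxy on an aromatic carbon, para to a large group: (trifluoromethyl)sulfanyl in place of hydroxy on an aromatic carbon. Among the measured compounds shown here, the only measured step, a 1.5-fold higher number from compound 1 to compound 2 (0.18 log units; within the scatter), stays within the scatter and does not involve the entering group, so it is a weak guide. A modest rise in this assay is tentatively expected, with a wide range. The expected step is a 2.0-fold higher number from compound 2 to compound 3 (0.30 log units; within the scatter). The estimate for compound 3 is 6 10^-6 cm/s, with an expected range of 2 10^-6 cm/s to 18 10^-6 cm/s.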

Compound 3, apparent permeability: 206 10^-6 cm/s
Estimate against measurement, compound 3: 34-fold (1.54 log units) below; the whole stated range lies below it.
By their numbers in this assay, from the lowest: compounds 1 and 2 (each within the scatter of the next); then compound 3.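

Among the compounds shown here, on an aromatic carbon para to a large group, (trifluoromethyl)sulfanyl is the first group to move the number in this assay beyond the scatter, both in place of hydroxy (a 69-fold higher number from compound 2 to compound 3 (1.84 log units; beyond the scatter)) and in place of dimethylamino (a 100-fold higher number from compound 1 to compound 3 (2.01 log units; beyond the scatter)). Hydroxy and dimethylamino did not separate at this position, so the pair gave no sign that it could respond this strongly. Nothing measured here accounts for the size of the step.

Open: whether a trifluoromethyl group, a methylsulfanyl group or a chlorine atom in this place would give a similar number, and so whether the sulfur or the fluorine atoms matter.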